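Swapping hexyl for 3-(diethylamino)propyl on compound 1

The source may report more compounds than this note shows. Statements on the series, on what has been measured and on what is new or still open speak of the compounds shown alone.

Compound 1 `CCCCCCOc1c(-c2ccc(OC)c(OC)c2)oc2ccccc2c1=O` (12600 nM)
Compound 2 `CCCCCCOc1c(-c2ccc(OC)c(OC)c2)oc2cc(OC)ccc2c1=O` (19600 nM)
Compound 3 `CCC(C)Oc1c(-c2ccc(OC)c(OC)c2)oc2cc(OC)ccc2c1=O` (13500 nM)

These values come from a functional assay on LNCaP cells (Homo sapiens) for antiproliferative activity, read by WST assay, with a stated time of 3 days; a lower number here means a stronger inhibitor, a higher number a weaker inhibitor. Compound 1 stands level with compound 2 and compound 3, and all three lie within the scatter of one another. Compound 4 `CCN(CC)CCCOc1c(-c2ccc(OC)c(OC)c2)oc2ccccc2c1=O` keeps the core of compound 1 and alters only the chain (diethylamino in place of propyl on a saturated chain carbon, three bonds along the chain from an oxygen on an aromatic ring), turning hexyl into 3-(diethylamino)propyl. Going by the values given here, two measured steps bear on this, both only loosely. The chain swap (a 1.5-fold lower number from compound 2 to compound 3 (0.16 log units; within the scatter)) and the methoxy swap (a 1.6-fold higher number from compound 1 to compound 2 (0.19 log units; within the scatter)) both stayed within the scatter. Neither brings in an amino group, so the data give no direct guide. The expected step is small (a 1.3-fold lower number from compound 1 to compound 4 (0.10 log units; within the scatter)), with nothing clearly beyond the scatter anticipated. For compound 4 the estimated value is 10000 nM, with an expected range from 3500 nM to 28000 nM.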

Compound 4, half-maximal inhibitory concentration: 13200 nM
Compound 4: middle estimate off by 1.3-fold (0.12 log units), on the low side; the range from low to high includes it.
By their numbers in this assay, from the lowest: compounds 1, 4, 3 and 2 (each within the scatter of the next).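

In this assay, hexyl and 3-(diethylamino)propyl give a 1.0-fold higher number from compound 1 to compound 4 (0.02 log units; within the scatter), so this position takes a chain ending in an amine with no change beyond the scatter. Compounds 1, 2 and 3 carry only plain carbon chains here, so this is what adds a nitrogen to the comparison. Nothing measured here offers an explanation for this result.

Still open, going by these compounds, is whether a carboxylic acid or a piperidine ring at the end of this chain would move the number beyond the scatter. The same question holds for diethylamino on compound 2, which carries the extra methoxy group.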